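A few compounds are considered here, and "the series" means these few. Any claim that something is new, unique, unknown or untested is made for them only; others in the source may bear on it.

Working notes on a small series of succinimide-bearing piperazine amides tested in a functional assay on the whole organism (strain Swiss) with Mus musculus as the target, in the maximal electroshock model, with a stated time of 2 h, at a dose of 300 mg/kg by the intraperitoneal route; a higher number here means a stronger effect of the compound at the dose given, a lower number a weaker effect.

Compound 3 `CC(C(=O)N1CCN(c2cccc(Cl)c2)CC1)N1C(=O)CCC1=O` is the reference point; in this assay compound 3 gives 50%. Compound 1 `CC(C(=O)N1CCN(c2ccc(Cl)cc2)CC1)N1C(=O)CCC1=O` carries the change (4-chlorophenyl in place of 3-chlorophenyl on an amine nitrogen in a ring), and in this assay compound 1 gives 0%. That single change makes the step of a number 50 percentage points lower from compound 3 to compound 1 (beyond the scatter), the largest movement in the set. Compound 2 `CCC(C(=O)N1CCN(c2cccc(Cl)c2)CC1)N1C(=O)CCC1=O` differs from compound 3 by methyl in place of hydrogen on a saturated chain carbon, two bonds along the chain from an amide-type nitrogen in a ring and a carbonyl carbon, and in this assay compound 2 gives 25%; the step of a number 25 percentage points higher from compound 2 to compound 3 (beyond the scatter) shows that the shorter chain is the more active of the pair here.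

Compound 4 `CCC(C(=O)N1CCN(c2ccc(Cl)cc2)CC1)N1C(=O)CCC1=O` is not yet measured. Among the measured compounds shown here, it stands to compound 2 as compound 1 stands to compound 3: the change 4-chlorophenyl in place of 3-chlorophenyl on an amine nitrogen in a ring is the same change as the one from compound 3 to compound 1, made on the same place, while the two cores differ as given by methyl in place of hydrogen on a saturated chain carbon, two bonds along the chain from an amide-type nitrogen in a ring and a carbonyl carbon. On the methyl core that change cost the full activity seen, a number 50 percentage points lower from compound 3 to compound 1 (beyond the scatter). Compound 2 starts from a lower level, as the step of a number 25 percentage points higher from compound 2 to compound 3 (beyond the scatter) shows; in this assay compound 2 gives 25%. The expected step is therefore a number 25 percentage points lower from compound 2 to compound 4 (beyond the scatter), bounded by the floor of the read-out, since a drop of the size seen from compound 3 to compound 1 cannot be realised from the level of compound 2. For compound 4 the expected value in this assay is 0%, with a range of 0% to 15%. For the measured compounds named here, only two steps inform this, so the estimate rests on a thin base.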

Compound 4, a percentage reported as activity, at one dose (the size of the read-out at that dose, not a potency): 25%
Compound 4: middle estimate off by 25 percentage points, on the low side; the measured number lies above the stated range.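

In this assay, 4-chlorophenyl in place of 3-chlorophenyl on the core of compound 2 gives no change at the digits printed from compound 2 to compound 4 (within the scatter), while methyl in place of hydrogen on the saturated chain carbon, with 4-chlorophenyl present, gives a number 25 percentage points higher from compound 1 to compound 4 (beyond the scatter). The chlorophenyl change therefore does not keep its size when carried from one core to the other, so the step seen on the core of compound 3 cannot be assumed for the core of compound 2: the same change on two cores in this assay, a number 50 percentage points lower (beyond the scatter) from compound 3 to compound 1 and no change at the digits printed (within the scatter) from compound 2 to compound 4, 50 percentage points apart, beyond the scatter of two such steps. The chain change likewise reverses its direction with the chlorophenyl group present, which shows that the two places do not act independently among these compounds, but does not show why this happens or whether it would hold at another dose: the same change on two cores in this assay, a number 25 percentage points higher (beyond the scatter) from compound 2 to compound 3 and a number 25 percentage points lower (beyond the scatter) from compound 4 to compound 1, 50 percentage points apart, beyond the scatter of two such steps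

The compounds shown leave open whether this dependence extends to other groups at the same place on the piperazine side, such as an unsubstituted phenyl or a trifluoromethyl group in place of the chlorine. They also leave open how a longer chain on the saturated carbon would behave with either chlorophenyl group, and whether the pattern in this assay would persist in a full dose-response comparison.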